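A few compounds are considered here, and "the series" means these few. Any claim that something is new, unique, unknown or untested is made for them only; others in the source may bear on it.

Of the compounds shown here, two have numbers so far. In an ADME assay (liver) for metabolic stability, with Liver microsome (Homo sapiens) as the target, read by LC-MS, using microsomes, with a stated time of 30 min, tested at 4 uM (on this read-out higher numbers stand for a more stable compound and lower numbers for a less stable compound), compound 1 `Cc1nc(N2CCN(C)CC2)c2nc(-c3ccccc3Cl)n(CCO)c2n1` gives 13% on the shared core. Compound 2 `Cc1nc(N2CCN(C)CC2)c2nc(-c3ccccc3C(F)(F)F)n(C3CCOCC3)c2n1` gives 24% as the higher of the two numbers, with compound 1 beyond the scatter under it. Going by the values given here, compound 1 and compound 2 differ in more than one place, so no single-change step is available as a guide. Compound 3 `CCc1ccccc1-c1nc2c(N3CCN(C)CC3)nc(C)nc2n1C1CCOCC1` is compound 2 with ethyl in place of trifluoromethyl on an aromatic carbon, ortho to a large group (ethyl in place of trifluoromethyl on an aromatic carbon). A modest fall in this assay is expected, close to the scatter in size, and the estimated change is a number 7 percentage points lower from compound 2 to compound 3 (within the scatter) as a working figure. Compound 1 at 13% shows how low the series has read so far, and that reading sets the lower side of the expectation. Compound 3 is expected at 17% with an estimated range from 7% to 30% in this read-out.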

Compound 3, percent of the compound remaining: 33%
The estimate for compound 3 lay 16 percentage points below the measured number, outside the stated range (above it).
By their numbers in this assay, from the lowest: compound 1; then compounds 2 and 3 (each within the scatter of the next).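

In this assay, the series now has its first single-change step, ethyl in place of trifluoromethyl on an aromatic carbon, ortho to a large group, and it reads a number 9 percentage points higher from compound 2 to compound 3 (within the scatter). This position therefore takes a two-carbon ethyl group in place of trifluoromethyl with no step beyond the scatter, so fluorine is not needed here to hold the reading in this pair. No available measurement accounts for this step.

A single pair leaves open how far the position accepts other groups, such as methoxy, nitrile or a longer chain such as propyl. Compound 1 differs from compound 2 and compound 3 in more than one place, so the share of its chlorine and of its other differences cannot be separated.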